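Aryl cyanoguanidine variation on a benzopyran core

This account rests on a few compounds, and the source may have more. Where it says the series, first, only, none or still open, it means among the compounds named here.

Measured compounds:
compound 1 `CC1(C)Oc2ccc(C#N)cc2[C@@H](NC(=O)Nc2ccccn2)[C@@H]1O` gives 440 nM
compound 2 `CC1(C)Oc2ccc(C#N)cc2[C@@H](n2cc(C#N)c3ccccc32)[C@@H]1O` gives 2200 nM
compound 3 `CC1(C)Oc2ccc(C#N)cc2[C@@H](/N=C(\NC#N)Nc2ccc([N+](=O)[O-])cc2)[C@@H]1O` gives 300 nM

All three compounds share the same core and differ only in the group attached to it. In a functional assay (aorta) with Rattus norvegicus as the target (on this read-out lower numbers stand for stronger inhibition and higher numbers for weaker inhibition), compound 3 gives 300 nM, the lowest of the three numbers. Compound 1 sits close to it, and that gap lies within the usual scatter, so the two cannot be ranked. Compound 2 lies clearly further away, beyond the scatter, so compound 3 inhibits more strongly than compound 2.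

Compound 4 `CSc1cccc(N/C(=N/[C@@H]2c3cc(C#N)ccc3OC(C)(C)[C@H]2O)NC#N)c1` has not yet been measured. It keeps the cyanoguanidine of compound 3 and changes the aryl group on it: 3-(methylsulfanyl)phenyl in place of 4-nitrophenyl on an amine nitrogen. Among the measured compounds shown here, no measured pair in this set shows such a change, so its effect is unknown. The expectation for compound 4 therefore rests only on the value of compound 3, and the step of a 2.0-fold higher number from compound 3 to compound 4 (0.30 log units; within the scatter) is expected to be modest, plausibly toward a somewhat higher number. Compound 4 is estimated at 600 nM, within 150 nM to 2500 nM.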

Compound 4, half-maximal inhibitory concentration: 1400 nM
Compound 4: middle estimate off by 2.3-fold (0.37 log units), on the low side; measured number inside the range.
By their numbers in this assay, from the lowest: compounds 3 and 1 (each within the scatter of the next); then compounds 4 and 2 (each within the scatter of the next).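

In this assay, among the compounds shown here, the aryl group on the cyanoguanidine clearly matters: placing 3-(methylsulfanyl)phenyl instead of 4-nitrophenyl on the amine nitrogen gives a 4.7-fold higher number from compound 3 to compound 4 (0.67 log units; beyond the scatter), the only single-place change in this set. This position therefore does not treat all aryl groups alike, even though both groups carry one six-membered aromatic ring of carbon only. Nothing available here accounts for the rise in the number.

The step changes both the group and its place on the phenyl ring, so the compounds shown cannot separate these two changes; 3-nitrophenyl and 4-(methylsulfanyl)phenyl would connect them. As far as these compounds go, how an unsubstituted phenyl ring, or a phenyl ring bearing an amine or a carboxylic acid, would read at this position also remains open.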